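Removing the drawn configuration at the diol carbon

A few compounds are considered here, and "the series" means these few. Any claim that something is new, unique, unknown or untested is made for them only; others in the source may bear on it.

Compound 1 `CN1CCN(CCCCCn2c3c(c4ccccc42)C(=O)c2c[n+]([O-])c4ccccc4c2C3=O)CC1` and compound 2 `O=C1c2c[n+]([O-])c3ccccc3c2C(=O)c2c1c1ccccc1n2Cc1cn(C[C@@H](O)CO)nn1` share a core and differ only in the group on the saturated chain carbon bound to the aromatic nitrogen. In a functional assay on A-375 cells (Homo sapiens) for cytotoxicity, read by MTT assay, with a stated time of 72 h (on this read-out higher numbers stand for weaker inhibition and lower numbers for stronger inhibition), compound 1 gives 1710 nM, whereas compound 2 gives 140 nM, the lowest of the two numbers shown; the step of a 12-fold lower number from compound 1 to compound 2 (1.09 log units; beyond the scatter) is large. Compound 3 `O=C1c2c[n+]([O-])c3ccccc3c2C(=O)c2c1c1ccccc1n2Cc1cn(CC(O)CO)nn1` has not yet been measured in this assay. The change from compound 2 to compound 3 is the two compounds have the same atoms and bonds; at least one stereo element is drawn with a configuration in one of them and without one in the other: 1 of 1 stereo elements differ; a stereocentre at a saturated chain carbon is drawn R in compound 2 and without a configuration in compound 3. Going by the values given here, no measured step bears directly on this kind of change, since the only measured step, a 12-fold lower number from compound 1 to compound 2 (1.09 log units; beyond the scatter), replaces a whole side group rather than a drawn configuration. With the same atoms and bonds present, compound 3 is expected to sit close to compound 2, so the step of a 1.4-fold higher number from compound 2 to compound 3 (0.13 log units; within the scatter) is estimated to lie within the scatter or at most slightly upward. For compound 3 the estimated value in this assay is 190 nM, within a range from 70 nM to 550 nM.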

Compound 3, half-maximal inhibitory concentration: 440 nM
For compound 3 the middle estimate is 2.3-fold (0.36 log units) below the measured one; the range from low to high includes it.
By their numbers in this assay, from the lowest: compound 2; then compound 3; then compound 1.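

In this assay, a change in the drawing alone still registers, with no atom or bond altered: the values show a 3.1-fold higher number from compound 2 to compound 3 (0.50 log units; beyond the scatter). The earlier step replaced a whole side group, so it could not show that the drawn configuration at this saturated chain carbon goes with a modest difference of its own. The side-group replacement also remains visible without a defined configuration, as a 3.9-fold lower number from compound 1 to compound 3 (0.59 log units; beyond the scatter), and what separates compound 3 from compound 2 is only this: the fact that one of compounds 2 and 3 is drawn with a defined configuration and the other without, at the place where they differ

The compounds shown leave open how the opposite configuration at the diol carbon would read, since only the R drawing and the undefined drawing appear. They also leave open whether a primary amine or a carboxylic acid in place of the 2,3-dihydroxypropyl group on the triazole would hold the lower numbers.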